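Second chloro on the anilide ring of compound 3

The compounds below may be only part of what the source reports. "The series", "measured", "known", "first", "only" and "open" are said of these compounds alone.

Measured so far:
Compound 1 `O=C(CSc1nc(Nc2ccccc2)c2ccccc2n1)Nc1ccccc1F` in a functional assay on MDA-MB-231 cells (Homo sapiens) for inhibition, read by MTT assay, with a stated time of 72 h (a lower number here means a stronger inhibitor, a higher number a weaker inhibitor), gives > 50000 nM, a limit of the assay.
Compound 2 `O=C(CSc1nc(Nc2ccccc2)c2ccccc2n1)Nc1cccc(F)c1` in this assay gives > 50000 nM, also a limit.
Compound 3 `O=C(CSc1nc(Nc2ccccc2)c2ccccc2n1)Nc1ccc(Cl)cc1` in this assay gives 17200 nM.

Compound 3 carries the only number shown; the other two values are limits (the limit of > 50000 nM in this assay, at which 2 of the 3 values shown sit). The step from compound 1 to compound 3 reads an at least 2.9-fold lower number from compound 1 to compound 3 (0.46 log units; beyond the scatter), and from compound 2 to compound 3 an at least 2.9-fold lower number from compound 2 to compound 3 (0.46 log units; beyond the scatter). Compound 4 `O=C(CSc1nc(Nc2ccccc2)c2ccccc2n1)Nc1ccc(Cl)c(Cl)c1` differs from compound 3 by chloro in place of hydrogen on an aromatic carbon. For the measured compounds named here, no measured step adds a second chloro, so only the direction from the halogen steps above bears on it. A modest lowering is expected, a 2.2-fold lower number from compound 3 to compound 4 (0.33 log units; beyond the scatter). The estimate for compound 4 in this assay is 8000 nM, ranging from 2500 nM to 25000 nM.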

Compound 4, half-maximal inhibitory concentration: 14500 nM
For compound 4 the middle estimate is 1.8-fold (0.26 log units) below the measured one, and the stated range covers the measured number.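

In this assay, chloro in place of hydrogen ortho to the chloro group gives no readable change: a 1.2-fold lower number from compound 3 to compound 4 (0.07 log units; within the scatter). Compound 4 keeps the separation from the fluorophenyl anilides, with an at least 3.4-fold lower number from compound 2 to compound 4 (0.53 log units; beyond the scatter) and an at least 3.4-fold lower number from compound 1 to compound 4 (0.53 log units; beyond the scatter). Both of those steps are bounded on one side only: the limit of > 50000 nM in this assay, at which 2 of the 4 values shown sit.

Open, going by these compounds, is whether a non-halogen group at this place, such as methoxy, trifluoromethyl or an amine, would move the number beyond the scatter. Also open, on these data alone, is whether a change away from the anilide ring would do so.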